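The source may report more compounds than this note shows. Statements on the series, on what has been measured and on what is new or still open speak of the compounds shown alone.

In a functional assay on NB1 cells (Homo sapiens) for cytotoxicity, read by MTT assay, with a stated time of 3 days (on this read-out higher numbers stand for weaker inhibition and lower numbers for stronger inhibition), compound 1 `N#Cc1c(O)nc(SCc2nc3ccccc3[nH]2)nc1-c1ccccc1` gives 6.57 nM and compound 2 `N#Cc1c(NN)nc(SCc2nc3ccccc3[nH]2)nc1-c1ccccc1` gives 5.4 nM. Compound 3 `N#Cc1c(Nc2ccccc2)nc(SCc2nc3ccccc3[nH]2)nc1-c1ccccc1` gives 2.5 nM, the lowest number of the three, but it stands apart from the others by modest margins only. Compound 4 `CNc1nc(SCc2nc3ccccc3[nH]2)nc(-c2ccccc2)c1C#N` carries methyl in place of phenyl on a nitrogen on an aromatic ring, so anilino becomes methylamino (methyl in place of phenyl on a nitrogen on an aromatic ring).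

The closest measured precedent is a 2.2-fold lower number from compound 2 to compound 3 (0.33 log units; beyond the scatter), which also changes only the group on that nitrogen. The step of a 2.6-fold lower number from compound 1 to compound 3 (0.42 log units; beyond the scatter) is of similar size and also ends at the anilino group. By contrast, a 1.2-fold lower number from compound 1 to compound 2 (0.09 log units; within the scatter) shows no separation between the two compounds lacking the phenyl group. Going by the values given here, no compound with methyl on that nitrogen has been measured, so the precedent is indirect. Removing the phenyl is expected to reverse much of the gain seen in the step to compound 3, returning the number to about the level of compound 2 at 5.4 nM.

The expected change is a 2.1-fold higher number from compound 3 to compound 4 (0.32 log units; beyond the scatter), a modest step towards a higher number in this assay. For compound 4 the estimated value is 5.2 nM, with an expected range of 2.4 nM to 11 nM.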

Compound 4, half-maximal inhibitory concentration: 4.46 nM
Beside the measured number, compound 4's estimate is 1.2-fold (0.07 log units) above it; the range from low to high includes it.
By their numbers in this assay, from the lowest: compounds 3, 4, 2 and 1 (each within the scatter of the next, the first and the last beyond it).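

In this assay, methylamino in place of anilino on this nitrogen gives a 1.8-fold higher number from compound 3 to compound 4 (0.25 log units; within the scatter) and so stays within the scatter, although the steps from compound 1 and from compound 2 to compound 3 were both printed as beyond it. Compound 4 also does not separate from the two compounds without the phenyl: methyl in place of amino on that nitrogen gives a 1.2-fold lower number from compound 2 to compound 4 (0.08 log units; within the scatter) and methylamino in place of hydroxy on the aromatic carbon gives a 1.5-fold lower number from compound 1 to compound 4 (0.17 log units; within the scatter) in the same read-out. The phenyl group, with its six carbons and one aromatic ring, is therefore not required for a number in this range, and compound 3 is no longer set apart from every other compound in the series. Nothing on hand offers an explanation for how closely these numbers sit.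

Open, going by these compounds, is whether a longer chain such as n-butyl on that nitrogen, or a dimethylamino group in place of methylamino, would give a step beyond the scatter from compound 4. Also open, on these data alone, is whether a carboxylic acid or a methoxy group on the phenyl of compound 3 would widen or close its modest margins over compound 1 and compound 2.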